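This account rests on a few compounds, and the source may have more. Where it says the series, first, only, none or still open, it means among the compounds named here.

Compound 1 `O=C(O)CCC(=O)OCCCCCCSc1ccc([N+](=O)[O-])c2nonc12` is the acid of this small set. In an ADME assay on L02 cells (Homo sapiens) for cytotoxicity, read by MTT assay, with a stated time of 72 h (on this read-out lower numbers stand for stronger inhibition and higher numbers for weaker inhibition), compound 1 gives 1890 nM, the lowest of the three numbers measured. Its two amides sit higher: compound 2 `Cc1ccccc1NC(=O)CCC(=O)OCCCCCCSc1ccc([N+](=O)[O-])c2nonc12` gives 9490 nM and compound 3 `CCN(CC)CCCNC(=O)CCC(=O)OCCCCCCSc1ccc([N+](=O)[O-])c2nonc12` gives 6770 nM. The step of a 5.0-fold higher number from compound 1 to compound 2 (0.70 log units; beyond the scatter) and the step of a 3.6-fold higher number from compound 1 to compound 3 (0.55 log units; beyond the scatter) both show that replacing the hydroxy on the carbonyl carbon with an amino group raises the number beyond the scatter, while the step of a 1.4-fold lower number from compound 2 to compound 3 (0.15 log units; within the scatter) shows that the two amide substituents themselves are not separated by more than the scatter.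

Compound 4 `O=C(CCC(=O)OCCCCCCSc1ccc([N+](=O)[O-])c2nonc12)NCCN1CCCC1` has not yet been measured in this assay. Compared with compound 1 it carries the change ((2-(pyrrolidin-1-yl)ethyl)amino in place of hydroxy on a carbonyl carbon). Going by the values given here, the steps that bear on it are the two amide formations, from compound 1 to compound 2 and from compound 1 to compound 3, both modest rises; compound 4, like compound 3, carries a chain that ends in a basic nitrogen, so the latter step is the closer model. Compound 4 is therefore expected to give a higher number than compound 1 by a step of about a 3.4-fold higher number from compound 1 to compound 4 (0.54 log units; beyond the scatter), and its value in this assay is estimated at 6500 nM, within a range of 3000 nM to 14000 nM.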

Compound 4, half-maximal inhibitory concentration: 6580 nM
The estimate for compound 4 lay 1.0-fold (0.01 log units) below the measured number; the range from low to high includes it.
By their numbers in this assay, from the lowest: compound 1; then compounds 4, 3 and 2 (each within the scatter of the next).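

With (2-(pyrrolidin-1-yl)ethyl)amino in place of hydroxy on the carbonyl carbon, this assay again shows a modest rise (a 3.5-fold higher number from compound 1 to compound 4 (0.54 log units; beyond the scatter)), so a third amide, now one bearing a five-membered non-aromatic ring, sits beyond the scatter from the acid. The ring adds no separation from the open diethylamino chain (a 1.0-fold lower number from compound 3 to compound 4 (0.01 log units; within the scatter)), and the 2-methylphenyl amide is not separated from compound 4 either (a 1.4-fold lower number from compound 2 to compound 4 (0.16 log units; within the scatter)). Among these four compounds, then, the step that exceeds the scatter is the replacement of hydroxy by an amine-derived group, while the three groups carried on the amide nitrogen remain indistinguishable, and no compound here goes against this pattern.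

Nothing available here accounts for why the amides stand above the acid in this read-out. On these data alone, it remains open whether a methyl ester at this carbonyl carbon would stand with the acid or with the amides, and whether a morpholin-4-yl group or a longer chain on the amide nitrogen would stay within the scatter of compound 4.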